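Swapping Dichlorophenyl for Dimethoxyphenyl in a Weak Series

The source may hold more compounds than are shown below. What is called first, only, known or untested is meant among the compounds shown, and "the series" means these compounds.

In a functional assay on K562 cells (Homo sapiens) for antiproliferative activity, with a stated time of 72 h (on this read-out lower numbers stand for stronger inhibition and higher numbers for weaker inhibition), compound 1 (`OC[C@H]1O[C@@H](n2cnc3c(NCc4ccc(Cl)cc4)ncnc32)[C@H](O)[C@@H]1O`) gives 218000 nM and compound 2 (`OC[C@H]1O[C@@H](n2cnc3c(NCc4ccc(Cl)cc4Cl)ncnc32)[C@H](O)[C@@H]1O`) gives 106000 nM, the lower of the two numbers. Compound 3 (`COc1cc(CNc2ncnc3c2ncn3[C@@H]2O[C@H](CO)[C@@H](O)[C@H]2O)cc(OC)c1`) has 3,5-dimethoxyphenyl in place of 2,4-dichlorophenyl on a saturated chain carbon bound to a nitrogen on an aromatic ring. Within the data shown here, the only measured step, a 2.1-fold lower number from compound 1 to compound 2 (0.31 log units; beyond the scatter), is modest and bears only partly on this change, since it adds a single chloro. A slight drift to a higher number is expected, but no step beyond the scatter: the estimated step is a 1.5-fold higher number from compound 2 to compound 3 (0.18 log units; within the scatter). Compound 3 is expected at 160000 nM, with an estimated range of 60000 nM to 400000 nM.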

Compound 3, half-maximal inhibitory concentration: > 166000 nM
Compound 3: no number, only a limit; the forecaster's own chance of this, stated with the estimate: 20%; middle value at least 1.0-fold (0.01 log units) away from the limit.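

Compound 3 gives only a limit in this assay, not a number: the limit of > 166000 nM in this assay, at which 1 of the 3 values shown sits. Exchanging 2,4-dichlorophenyl for 3,5-dimethoxyphenyl at this place gives an at least 1.5-fold higher number from compound 2 to compound 3 (0.19 log units; that floor lies within the scatter), so the two methoxy groups bring no gain over the two chloro atoms, although this floor does not separate the two compounds. The step from compound 1 to compound 3 cannot be read.

On these data alone, how far the true value of compound 3 lies past its limit remains open. So does whether an amine or a carboxylic acid on this aromatic ring, or a longer chain, would bring the number down.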